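Phenylsulfonyl to (4-chlorophenyl)sulfonyl: cytotoxicity outlook

The source may report more compounds than this note shows. Statements on the series, on what has been measured and on what is new or still open speak of the compounds shown alone.

Two analogues of the shared core carry numbers in an ADME assay on L02 cells (Homo sapiens) for cytotoxicity, read by MTT assay, with a stated time of 24 h; on this read-out lower numbers stand for stronger inhibition and higher numbers for weaker inhibition. Compound 1 `O=C1/C(=C/c2cccc(F)c2)CN(S(=O)(=O)c2ccccc2)C/C1=C\c1cccc(F)c1` gives 16200 nM. Compound 2 `O=C1/C(=C/c2ccc(F)cc2)CN(S(=O)(=O)c2ccccc2)C/C1=C\c1ccc(F)cc1` gives 18800 nM in this assay, and the two values lie within the scatter of each other, so nothing separates them. Compound 3 `O=C1/C(=C/c2ccc(F)cc2)CN(S(=O)(=O)c2ccc(Cl)cc2)C/C1=C\c1ccc(F)cc1` differs from compound 2 by chloro in place of hydrogen on an aromatic carbon. Among the measured compounds shown here, no measured pair shows this change, so its size is unknown here. For compound 3 the expected step is a 1.3-fold lower number from compound 2 to compound 3 (0.10 log units; within the scatter), nothing beyond the scatter. Compound 3 is therefore estimated at 15000 nM, with a range from 6000 nM to 40000 nM.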

Compound 3, half-maximal inhibitory concentration: 15500 nM
Compound 3: middle estimate off by 1.0-fold (0.01 log units), on the low side, within the range that was stated.
By their numbers in this assay, from the lowest: compounds 3, 1 and 2 (each within the scatter of the next).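

In this assay, phenylsulfonyl to (4-chlorophenyl)sulfonyl gives a 1.2-fold lower number from compound 2 to compound 3 (0.08 log units; within the scatter), so this position tolerates chloro in place of hydrogen without a shift beyond the scatter. Among the compounds shown here, this is the only reading of a change at the sulfonyl aryl group, as compound 1 and compound 2 differ only at the fluorine-bearing aryl groups. No measured property bears on this result.

Going by these compounds, whether an amine or a carboxylic acid at this place would move the number beyond the scatter stays open. So does whether chloro behaves alike on the core of compound 1.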